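From compound 3 to compound 4

A few compounds are considered here, and "the series" means these few. Any claim that something is new, unique, unknown or untested is made for them only; others in the source may bear on it.

Values in a functional assay on DU-145 cells (Homo sapiens) for antiproliferative activity, read by sulforhodamine B assay, with a stated time of 48 h; a lower number here means a stronger inhibitor, a higher number a weaker inhibitor:
Compound 1 `CCCCN(C)C(=O)CCCOc1cc(OC)c(OC)c2oc(-c3ccc(OC)cc3)c(O)c(=O)c12`: > 40000 nM, a limit
Compound 2 `CCCCN(C)C(=O)CCCCOc1cc(OC)c(OC)c2oc(-c3ccc(OC)cc3)c(O)c(=O)c12`: 10800 nM
Compound 3 `COc1ccc(-c2oc3c(OC)c(OC)cc(OCCCCC(=O)N4CCN(C)CC4)c3c(=O)c2O)cc1`: > 40000 nM, a limit

Compound 3 has no true number, only the limit > 40000 nM. That places compound 3 at the limit of > 40000 nM in this assay, at which 2 of the 3 values shown sit.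

Compound 4 `CCCCCN(C)C(=O)CCCCCOc1cc(OC)c(OC)c2oc(-c3ccc(OC)cc3)c(O)c(=O)c12` changes this structure as follows: (methyl(pentyl)carbamoyl)methyl in place of (4-methylpiperazin-1-yl)carbonyl on a saturated chain carbon, four bonds along the chain from an oxygen on an aromatic ring. Put simply, (methyl(pentyl)carbamoyl)methyl stands in place of (4-methylpiperazin-1-yl)carbonyl, on a saturated chain carbon, four bonds along the chain from an oxygen on an aromatic ring.

Among the compounds with values here, two measured steps bear on this change. Putting 4-methylpiperazin-1-yl in place of butyl(methyl)amino gave an at least 3.7-fold higher number from compound 2 to compound 3 (0.56 log units; beyond the scatter), and compound 4 reverses that kind of swap. Lengthening the chain gave an at least 3.7-fold lower number from compound 1 to compound 2 (0.56 log units; beyond the scatter). As far as these compounds go, both steps rest on a limit, so their full sizes are unknown, but both suggest a lower number in this assay. The expected result is an at least 8.0-fold lower number from compound 3 to compound 4 (0.90 log units; beyond the scatter). Compound 4 is estimated at 5000 nM, with an expected range of 1500 nM to 20000 nM.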

Compound 4, half-maximal inhibitory concentration: 22500 nM
Beside the measured number, compound 4's estimate is 4.5-fold (0.65 log units) below it; the measured number lies above the stated range.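

In this assay, within the data shown here, the earlier compounds gave a lower number as the chain grew, but compound 4 goes against that pattern, with a 2.1-fold higher number from compound 2 to compound 4 (0.32 log units; beyond the scatter), where the chain and the alkyl group on the amide nitrogen are both larger. Its steps from the two compounds held at a limit are an at least 1.7-fold lower number from compound 3 to compound 4 (0.24 log units; that floor lies within the scatter) and an at least 1.7-fold lower number from compound 1 to compound 4 (0.24 log units; that floor lies within the scatter). These are only floors and fix no true size: the limit of > 40000 nM in this assay, at which 2 of the 4 values shown sit.

Compound 4 differs from compound 2 in the chain and the pentyl group together, so the compounds shown do not separate these two changes. As far as these compounds go, it remains open how butyl(methyl)carbamoyl would behave on the longer chain, and whether an amine or a carboxylic acid at the chain end, in place of the amide, would give a lower number.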